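Benzyl-to-benzoyl switch at the five-membered ring carbon

The source may hold more compounds than are shown below. What is called first, only, known or untested is meant among the compounds shown, and "the series" means these compounds.

Measured in an assay on isolated protein for inhibition of Long-chain-fatty-acid--CoA ligase 1 (Homo sapiens), read by mass spectrometry, with a stated time of 90 min, in the presence of a further agent that is not named here; on this read-out lower numbers stand for stronger inhibition and higher numbers for weaker inhibition:
- compound 1 `Cc1cccc(Cc2cc3cc(O[C@H]4CC[C@@H](C(=O)O)CC4)ccc3n2C)c1`: 400 nM
- compound 2 `Cc1cccc(Cc2nc3ccc(O[C@H]4CC[C@@H](C(=O)O)CC4)cc3n2C)c1`: a limit of this assay, > 200000 nM
- compound 3 `Cn1c(Cc2cccc(C#N)c2)nc2cc(O[C@H]3CC[C@@H](C(=O)O)CC3)ccc21`: 51000 nM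

Compound 3 gives the higher of the two numbers obtained in this assay, compound 1 the lower, and compound 2 sits at the limit of > 200000 nM in this assay, at which 1 of the 3 values shown sits, rather than at a number. No two of the measured compounds differ in only one place, so no single step can be read off.

Compound 4 `Cc1cccc(C(=O)c2nc3cc(O[C@H]4CC[C@@H](C(=O)O)CC4)ccc3n2C)c1` is the next compound to be measured in this assay. It differs from compound 3 by (3-methylphenyl)carbonyl in place of 3-cyanobenzyl on an aromatic carbon. The aromatic ring of compound 4 carries a methyl, as in compound 2, while the linking atom becomes a carbonyl.

The two measured compounds sharing the core of compound 3 both sit in the weak region, with compound 2 at the limit and compound 3 above the scatter from compound 1. A step from compound 3 to compound 4 of a 1.2-fold higher number from compound 3 to compound 4 (0.07 log units; within the scatter) is therefore expected, lying within the scatter or toward a weaker read-out. For compound 4 the estimate in this assay is 60000 nM, with a range from 10000 nM to 200000 nM.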

Compound 4, half-maximal inhibitory concentration: > 200000 nM
Compound 4 ended at the assay's limit; the forecaster's own chance of this, stated with the estimate: 30%; middle value at least 3.3-fold (0.52 log units) from the limit.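

At the ring carbon between two ring nitrogen atoms, (3-methylphenyl)carbonyl in place of 3-cyanobenzyl gives the series its first single-place comparison in this assay, with an at least 3.9-fold higher number from compound 3 to compound 4 (0.59 log units; beyond the scatter). Compound 4 gives a limit of the assay, > 200000 nM, so the step has a lower bound but no full size. Inhibition at this position therefore weakens further with this change, and more of the set now gives no number for ranking: the limit of > 200000 nM in this assay, at which 2 of the 4 values shown sit.

The change swaps the linking atom and the ring substituent together, so the shares of the carbonyl and of the exchange of nitrile for methyl remain unresolved. Also open, from the compounds shown here alone, is how this position would respond to a linking oxygen or amine nitrogen, or to a carboxylic acid on the aromatic ring.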